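A few compounds are considered here, and "the series" means these few. Any claim that something is new, unique, unknown or untested is made for them only; others in the source may bear on it.

Measured compounds:
Compound 1 `O=C1/C(=C/c2ccc(F)cc2)CCC/C1=C\c1ccc([N+](=O)[O-])cc1` gives 18600 nM in a functional assay on CCRF-CEM cells (Homo sapiens) for cytotoxicity, with a stated time of 72 h; a higher number here means a weaker inhibitor, a lower number a stronger inhibitor.
Compound 2 `O=C1CCCC/C1=C\c1ccc([N+](=O)[O-])cc1` gives 19300 nM in this assay.
Compound 3 `Cc1ccc(/C=C2\CCC/C(=C\c3ccccc3[N+](=O)[O-])C2=O)cc1` gives 6090 nM in this assay.

Among these three values, compound 1 stands with the second highest number. Its nearest neighbour is compound 2, whose value sits within the scatter of compound 1, so the two cannot be ordered. Compound 3 lies furthest from compound 1, with a lower number, and that gap is beyond the scatter.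

The account now turns to compound 4 `CN(C)c1ccc(/C=C2\CCC/C(=C\c3ccc([N+](=O)[O-])cc3)C2=O)cc1`, which has not yet been measured in this assay. Compound 4 differs from compound 1 in one place: dimethylamino in place of fluoro on an aromatic carbon. For the measured compounds named here, no pair of measured compounds shows this change, so nothing here tells how dimethylamino in place of fluoro on an aromatic carbon shifts the number. On that footing the step from compound 1 to compound 4 is expected to be small, most likely no larger than the scatter, as a 1.2-fold lower number from compound 1 to compound 4 (0.09 log units; within the scatter) expresses. The estimate for compound 4 in this assay is therefore 15000 nM, with a range from 4000 nM to 45000 nM.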

Compound 4, half-maximal inhibitory concentration: > 500000 nM
Compound 4: a limit, no number; the forecaster's own chance of this, stated with the estimate: 10%; middle value at least 33-fold (1.52 log units) from the limit.
By their numbers in this assay, from the lowest: compound 3; then compounds 1 and 2 (each within the scatter of the next). At a limit, above all of these: compound 4.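

In this assay compound 4 gives > 500000 nM, which is a limit of the assay and not a number. On an aromatic carbon para to a large group, the change from 4-fluorophenyl to 4-(dimethylamino)phenyl brings an at least 26-fold higher number from compound 1 to compound 4 (1.42 log units; beyond the scatter), so the compound becomes a clearly weaker inhibitor. Before this result no measured pair spoke to this place, and it now shows that the number can respond strongly to the group standing there, with the true size of the step left unfixed by the limit: the limit of > 500000 nM in this assay, at which 1 of the 4 values shown sits.

The compounds shown leave open whether a plain amino group, a methoxy group or a hydroxyl group at this place would shift the number as far. They also rest on this single pair, so they do not tell what in the dimethylamino group lies behind the step.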